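The source may report more compounds than this note shows. Statements on the series, on what has been measured and on what is new or still open speak of the compounds shown alone.

In an ADME assay on HepG2 2.2.15 cells (Homo sapiens) for cytotoxicity, read by MTT assay, with a stated time of 8 days (a higher number here means that more compound is tolerated, a lower number that less compound is tolerated), three compounds have been measured so far. Compound 1 `CC(=O)Nc1ccc(-c2nn(Cc3ccc(C#N)cc3)c(=O)c3ccccc23)c(F)n1` gives > 100000 nM, which is a limit of the assay and not a number. Compound 2 `O=c1c(CO)cc(-c2ccc(F)nc2F)nn1Cc1ccc(Cl)cc1` gives > 100000 nM, which is likewise a limit. For the measured compounds named here, compound 3 `N#Cc1ccc(Cn2nc(-c3cc(Cl)c(NCCO)nc3F)c3ccccc3c2=O)cc1` gives 32100 nM, the only actual number among the three, so it has no measured neighbour to be placed against.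

The next compound to be tested is compound 4 `COCCNc1nc(F)c(-c2nn(Cc3ccc(C#N)cc3)c(=O)c3ccccc23)cc1Cl`. It differs from compound 3 at one place, with methyl in place of hydrogen on an oxygen on a saturated carbon, so that 2-hydroxyethyl becomes 2-methoxyethyl: methyl in place of hydrogen on an oxygen on a saturated carbon.

Going by the values given here, no measured pair of compounds in this assay differs at only one place, so the data give no direct guide to the size of such a step. The expectation is therefore no step beyond the usual scatter, in either direction. It rests on compound 3 at 32100 nM. The range is kept wide, and the assay could also return only a limit. The expected change is a 1.1-fold higher number from compound 3 to compound 4 (0.04 log units; within the scatter). For compound 4 the estimated half-maximal cytotoxic concentration is 35000 nM, with an expected range from 12000 nM to 100000 nM.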

Compound 4, half-maximal cytotoxic concentration: > 100000 nM
Compound 4: no number, only a limit; the forecaster's own chance of this, stated with the estimate: 25%; middle value at least 2.8-fold (0.45 log units) away from the limit.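

In this assay, for the compounds shown here, the change from 2-hydroxyethyl to 2-methoxyethyl is the first change at a single place that can be read, and it gives an at least 3.1-fold higher number from compound 3 to compound 4 (0.49 log units; beyond the scatter). So methyl in place of hydrogen on this oxygen on a saturated carbon moves the number by more than the usual scatter, and the direction is towards more compound being tolerated, which the earlier compounds alone could not show. Compound 4 gives > 100000 nM, which is a limit of the assay and not a number, so the step has a lower bound but no known full size, and compound 3 remains the only compound with an actual number: the limit of > 100000 nM in this assay, at which 3 of the 4 values shown sit.

The compounds shown leave open whether the shift is tied to the methyl on this oxygen or would also appear with an ethyl group there, with a longer chain, or with an amine in place of the hydroxy. They also do not show whether the same change would give a step of this kind on the core of compound 2, or how far compound 4 actually lies from compound 3.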